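A few compounds are considered here, and "the series" means these few. Any claim that something is new, unique, unknown or untested is made for them only; others in the source may bear on it.

Compound 1 `Cc1c(CCCC(=O)O)c2cccc(/C=C/c3ccc(OCCCCc4c(F)c(F)cc(F)c4F)cc3)c2n1CC(=O)O` stands lowest of the two numbers measured. In a functional assay on HEK293 cells for antagonist activity at cysteinyl leukotriene receptor 2 (Homo sapiens), read by fluorescence and calcium flux, with stated times of 30 min and 1 h (a higher number here means a weaker inhibitor, a lower number a stronger inhibitor), compound 1 gives 3.7 nM, while compound 2 `Cc1c(Cl)cccc1CCCCOc1ccc(C#Cc2cccc3c(CC(=O)O)c(C)n(CCCCC(=O)O)c23)cc1` gives 248 nM, a gap beyond the scatter; the two compounds differ in several places at once, so nothing more than what the two values show can be said of that pair. Compound 3 `Cc1c(CCCC(=O)O)c2cccc(/C=C/c3ccc(OCCCCc4c(F)ccc(F)c4F)cc3)c2n1CC(=O)O` has not yet been measured. It differs from compound 1 in one place: hydrogen in place of fluoro on an aromatic carbon. Among the compounds with values here, no step between measured compounds carries a change of this kind, so there is no direct guide. Taking one fluoro from the 2,3,5,6-tetrafluorophenyl group is a small change, and the step of a 1.6-fold higher number from compound 1 to compound 3 (0.21 log units; within the scatter) is expected to be small, a modest weakening or none beyond the scatter. Compound 3 is therefore estimated at 6 nM, with a range from 2 nM to 20 nM.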

Compound 3, half-maximal inhibitory concentration in the cysteinyl leukotriene receptor 2 assay: 1 nM
The estimate for compound 3 lay 6.0-fold (0.78 log units) above the measured number, outside the stated range (below it).
By their numbers in the cysteinyl leukotriene receptor 2 assay, from the lowest: compound 3; then compound 1; then compound 2.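

Hydrogen in place of fluoro on this aromatic carbon, which turns the 2,3,5,6-tetrafluorophenyl group into the 2,3,6-trifluorophenyl group, gives the first reading of a single change in this series: in the cysteinyl leukotriene receptor 2 assay there is a 3.7-fold lower number from compound 1 to compound 3 (0.57 log units; beyond the scatter). This fluoro is therefore not required for inhibition, and compound 3, which lacks it, is the stronger inhibitor of the pair. The same change moves the other way for permeability, as seen in a physicochemical assay for permeability, using PAMPA, with a stated time of 4 h, at pH 6.2, tested at 50 uM (on this read-out lower numbers stand for lower permeability and higher numbers for higher permeability), where compound 1 gives 9.4 10^-6 cm/s and compound 3 gives 4.4 10^-6 cm/s: the measured apparent permeability of compound 1, 9.4 10^-6 cm/s, and of compound 3, 4.4 10^-6 cm/s, a 2.1-fold lower number (0.33 log units; beyond the scatter)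

Going by these compounds, whether a chloro or a methoxy group on this carbon would keep the lower number in the cysteinyl leukotriene receptor 2 assay remains open. So does whether replacing a further fluoro with hydrogen would shift inhibition and permeability in the same directions.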